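This account rests on a few compounds, and the source may have more. Where it says the series, first, only, none or still open, it means among the compounds named here.

Measured so far in a physicochemical assay for acid dissociation:
compound 1, `COc1cccc(CNCCCNc2ccnc3cc(CCC(C)C)ccc23)c1O`, gives 9.47
compound 2, `COc1cccc(CNCCCNc2ccnc3cc(Cc4cccc(C(F)(F)F)c4)ccc23)c1O`, gives 9.47
compound 3, `COc1ccc(F)cc1CNCCCNc1ccnc2cc(Cc3cccc(C(F)(F)F)c3)ccc12`, gives 9.47

The three measured compounds sit level in this assay. The change isobutyl in place of 3-(trifluoromethyl)phenyl on a saturated chain carbon bound to an aromatic carbon produced no change at the digits printed from compound 2 to compound 1 (within the scatter). The two cores differ by 5-fluoro-2-methoxyphenyl in place of 2-hydroxy-3-methoxyphenyl on a saturated chain carbon bound to an amine nitrogen, and that change gave no change at the digits printed from compound 2 to compound 3 (within the scatter). Compound 4, `COc1ccc(F)cc1CNCCCNc1ccnc2cc(CCC(C)C)ccc12`, is not yet measured. It differs from compound 3 by isobutyl in place of 3-(trifluoromethyl)phenyl on a saturated chain carbon bound to an aromatic carbon, the place being the same word for word as in the earlier pair, so this is the same change made a second time; in all it occurs twice among these compounds. The step of no change at the digits printed from compound 3 to compound 4 (within the scatter) is expected to be small because no change at the digits printed from compound 2 to compound 1 (within the scatter) lay within the scatter. Compound 4 is therefore estimated at 9.47, between 9.17 and 9.77.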

Compound 4, acid dissociation constant: 9.47
Estimate against measurement, compound 4: no gap at the digits printed, and the stated range covers the measured number.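

Read by this assay, isobutyl in place of 3-(trifluoromethyl)phenyl gave no change at the digits printed from compound 3 to compound 4 (within the scatter) and, on the other core, no change at the digits printed from compound 2 to compound 1 (within the scatter) while 5-fluoro-2-methoxyphenyl in place of 2-hydroxy-3-methoxyphenyl gave no change at the digits printed from compound 1 to compound 4 (within the scatter) on the isobutyl compounds. The change therefore carried from one core to the other with the step staying within the scatter both times, but two such flat steps show only that it stayed level on these two cores and say nothing about how a larger step would carry. Nothing shown here accounts for the level read-out.

The compounds shown leave open whether a carboxylic acid, an amine or a longer chain in place of isobutyl would also stay level with these four. They also leave open whether the same holds on any core beyond these two.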